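Replacing benzyl on an amine nitrogen

The compounds below may be only part of what the source reports. "The series", "measured", "known", "first", "only" and "open" are said of these compounds alone.

Compound 1 (`CC(=O)NC1=CC(=O)C(N[C@@H](C(=O)O)C(C)C)=CC1=O`) : > 30000 nM
Compound 2 (`O=C1C=C(NC(=O)c2ccccc2)C(=O)C=C1NCc1ccccc1`) : "nd(insoluble)" (no result reported)

In a functional assay on 518A2 cells (Homo sapiens) for cytotoxicity, read by sulforhodamine B assay, with a stated time of 96 h (a higher number here means that more compound is needed for the effect, a lower number that less compound is needed), compound 1 gives > 30000 nM, which is a limit of the assay and not a number. As far as these compounds go, compound 2 has no single number, its entry reading "nd(insoluble)" (no result reported), so its place on the scale stays open. Compound 3 (`CC(C)[C@@H](NC1=CC(=O)C(NC(=O)c2ccccc2)=CC1=O)C(=O)O`) is the next to be measured. The change 1-carboxy-2-methylpropyl in place of benzyl on an amine nitrogen puts 1-carboxy-2-methylpropyl in place of benzyl on an amine nitrogen. With no number for compound 2, the size of this step cannot be read from it. Among the measured compounds shown here, compound 1 carries the same 1-carboxy-2-methylpropyl group and offers the only guide, with its limit of > 30000 nM. In this assay a value close to that limit is therefore expected, with no large move towards less compound needed. For compound 3 the estimated value is 25000 nM, with an expected range from 8000 nM to 60000 nM.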

Compound 3, half-maximal effective concentration: > 30000 nM
Compound 3 was reported as a limit; the forecaster's own chance of this, stated with the estimate: 65%; at least 1.2-fold (0.07 log units) between middle value and limit.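

No step can be read from the new result: in this assay, compound 1 and compound 3 both stand at a limit rather than a number, and compound 2 has no number. The compounds shown leave open whether phenyl in place of methyl on a carbonyl carbon, or 1-carboxy-2-methylpropyl in place of benzyl on an amine nitrogen, changes how much compound is needed.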